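Trifluoromethoxy in place of trifluoromethyl in compound 3

A few compounds are considered here, and "the series" means these few. Any claim that something is new, unique, unknown or untested is made for them only; others in the source may bear on it.

In an ADME assay on liver for metabolic stability, with Liver microsome (Rattus norvegicus) as the target, read by LC-MS, using microsomes, with a stated time of 5 h (on this read-out higher numbers stand for fast clearance and lower numbers for slow clearance), compound 3 (`C[C@]1(O)C[C@@](c2ccc(C(F)(F)F)cc2)([C@H](O)c2ccccn2)C1`) gives 150 mL/min/kg. Compound 1 (`C[C@]1(O)C[C@](c2ccc(OC(F)(F)F)cc2)([C@H](O)c2ccccn2)C1`) gives 100 mL/min/kg, within the scatter of compound 3. Compound 2 (`O[C@H](c1ccccn1)[C@]1(c2ccc(C(F)(F)F)cc2)C[C@@H](O)C1`) gives 50 mL/min/kg, and only this gap lies beyond the scatter.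

Compound 4 (`C[C@]1(O)C[C@@](c2ccc(OC(F)(F)F)cc2)([C@H](O)c2ccccn2)C1`) carries trifluoromethoxy in place of trifluoromethyl on an aromatic carbon, para to a large group: trifluoromethoxy in place of trifluoromethyl on an aromatic carbon.

Among the measured compounds shown here, no measured step makes this exchange. For the measured compounds named here, the one measured step, a 3.0-fold higher number from compound 2 to compound 3 (0.48 log units; beyond the scatter), is modest but concerns methyl in place of hydrogen on a saturated ring carbon, so it gives no direct size for this change. The nearest evidence is compound 1, which also carries trifluoromethoxy and gives 100 mL/min/kg, so no clear move beyond the scatter is expected, and no direction is favoured strongly. The expected step is a 1.2-fold lower number from compound 3 to compound 4 (0.06 log units; within the scatter), within the scatter. Compound 4 is estimated at 130 mL/min/kg, with an expected range of 70 mL/min/kg to 240 mL/min/kg.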

Compound 4, clearance: 133 mL/min/kg
Compound 4: the middle estimate sits 1.0-fold (0.01 log units) below what was measured, and the stated range covers the measured number.
By their numbers in this assay, from the lowest: compounds 2, 1, 4 and 3 (each within the scatter of the next, the first and the last beyond it).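

In this assay, among the compounds shown here, trifluoromethoxy in place of trifluoromethyl on an aromatic carbon, para to a large group, gives a 1.1-fold lower number from compound 3 to compound 4 (0.05 log units; within the scatter), the first direct reading of this exchange, and at this position it does not separate the two groups. The second new comparison, a 1.3-fold higher number from compound 1 to compound 4 (0.12 log units; within the scatter), also stays within the scatter, and it isolates a change of a different kind: the fact that compounds 1 and 4 differ only in the configuration as drawn. Among the compounds shown, neither this exchange nor this change of configuration moves the clearance beyond the scatter, whereas a 3.0-fold higher number from compound 2 to compound 3 (0.48 log units; beyond the scatter) does.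

From the compounds shown here alone, whether a group of another kind on this aromatic carbon, such as an amine or a carboxylic acid, would move the number beyond the scatter stays open. Also open, going by these compounds, is whether the change of configuration would read the same with trifluoromethyl on the aromatic carbon.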